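A few compounds are considered here, and "the series" means these few. Any claim that something is new, unique, unknown or untested is made for them only; others in the source may bear on it.

Compound 1 `CCCCNC(=O)N1Cc2c(NC(=O)c3ccccc3)nn(C(=O)C3CC3)c2C1` gives 3470 nM
Compound 2 `CC(=O)n1nc(NC(=O)c2ccccc2)c2c1CN(C(=O)c1ccccc1)C2` gives 580 nM
Compound 3 `CCC(=O)n1nc(NC(=O)c2ccccc2)c2c1CN(C(=O)c1ccccc1)C2` gives 1060 nM

All three values come from a functional assay on HCT-116 cells (Homo sapiens) for cytotoxicity, read by sulforhodamine B assay, with a stated time of 48 h; on this read-out higher numbers stand for weaker inhibition and lower numbers for stronger inhibition. On these numbers compound 3 lies within the scatter of compound 2 , while compound 1 shows a higher number, and its gap to compound 3 lies beyond the scatter.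

Compound 4 `O=C(Nc1nn(C(=O)C2CC2)c2c1CN(C(=O)c1ccccc1)C2)c1ccccc1` has not yet been measured. It differs from compound 3 in one place, where propanoyl changes to cyclopropylcarbonyl, which is cyclopropyl in place of ethyl on a carbonyl carbon.

Within the data shown here, the one measured step at this carbonyl is a 1.8-fold higher number from compound 2 to compound 3 (0.26 log units; within the scatter), and it stays within the scatter. That step is a different change, methyl in place of hydrogen on a saturated chain carbon bound to a carbonyl carbon, so it offers only a rough guide. Compound 1 also carries cyclopropylcarbonyl, but it differs from compound 4 elsewhere as well, so it cannot isolate this change. Among the measured compounds shown here, no measured pair shows the ethyl to cyclopropyl change itself.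

On this limited evidence, no shift beyond the scatter is expected in this assay, and neither direction is favoured. The expected step is a 1.1-fold lower number from compound 3 to compound 4 (0.03 log units; within the scatter). For compound 4 the estimated value is 1000 nM, with an expected range from 450 nM to 2300 nM.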

Compound 4, half-maximal inhibitory concentration: 1240 nM
Estimate against measurement, compound 4: 1.2-fold (0.09 log units) below, within the range that was stated.
By their numbers in this assay, from the lowest: compounds 2, 3 and 4 (each within the scatter of the next, the first and the last beyond it); then compound 1.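

In this assay, the direct ethyl to cyclopropyl change on this carbonyl carbon gives a 1.2-fold higher number from compound 3 to compound 4 (0.07 log units; within the scatter), so adding the three-membered ring to the chain does not separate these two compounds. Measured against the smaller acetyl group, however, the same position does respond: cyclopropyl in place of methyl gives a 2.1-fold higher number from compound 2 to compound 4 (0.33 log units; beyond the scatter), a modest step and the only one at this carbonyl that passes the scatter, which shows that the group here is not wholly without effect even though neither single step along the series from acetyl shows it. Among these compounds, with cyclopropylcarbonyl held constant, compound 4 also gives the first clean reading of the other carbonyl, where phenyl in place of butylamino gives a 2.8-fold lower number from compound 1 to compound 4 (0.45 log units; beyond the scatter), a step of similar modest size.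

Nothing measured here accounts for any of these steps. From the compounds shown here alone, it remains open whether a longer chain such as butanoyl, or an acyl group carrying an amine or a carboxylic acid, would move the number further at this carbonyl, and whether the gap between acetyl and cyclopropylcarbonyl would persist with butylamino on the other carbonyl.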